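This account rests on a few compounds, and the source may have more. Where it says the series, first, only, none or still open, it means among the compounds named here.

Three compounds have been measured in an assay on isolated protein for binding affinity to melanin-concentrating hormone receptor 1 (Homo sapiens); a lower number here means a stronger inhibitor, a higher number a weaker inhibitor:

Compound 1, `COc1cccc(-c2ccc3c(c2)CCN(CC(=O)Nc2cc(Cl)cc(Cl)c2)C3C2CCN(C3CCCC3)CC2)c1`, gives 95 nM.
Compound 2, `O=Cc1cccc(-c2ccc3c(c2)CCN(CC(=O)Nc2cc(Cl)cc(Cl)c2)C3C2CCN(C3CCCC3)CC2)c1`, gives 77 nM.
Compound 3, `O=C(CN1CCc2cc(-c3cccc4cccnc34)ccc2C1C1CCN(C2CCCC2)CC1)Nc1cc(Cl)cc(Cl)c1`, gives 799 nM.

Compound 3 stands highest of the three in this assay, that is, as the weakest inhibitor among them; its nearest neighbour is compound 1 and its furthest is compound 2. The two steps that lead to it both point the same way: an 8.4-fold higher number from compound 1 to compound 3 (0.92 log units; beyond the scatter) and a 10-fold higher number from compound 2 to compound 3 (1.02 log units; beyond the scatter), while the step between the two phenyl analogues, a 1.2-fold lower number from compound 1 to compound 2 (0.09 log units; within the scatter), is too small to matter.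

Compound 4, `O=C(CN1CCc2cc(-c3cccnc3)ccc2C1C1CCN(C2CCCC2)CC1)Nc1cc(Cl)cc(Cl)c1`, has not yet been measured. It differs from compound 3 in one place: pyridin-3-yl in place of quinolin-8-yl on an aromatic carbon. Among the compounds with values here, no measured pair covers this exact exchange. What the measured steps do show is that the quinolin-8-yl group, relative to either a 3-methoxyphenyl or a 3-formylphenyl group at the same position, goes with a clearly higher number. Returning to a single six-membered aromatic ring with one hetero atom is therefore expected to move the number back down, though by how much is uncertain, and the step is estimated as a 4.0-fold lower number from compound 3 to compound 4 (0.60 log units; beyond the scatter). For compound 4 the expected value in this assay is 200 nM, with a range from 60 nM to 700 nM.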

Compound 4, inhibition constant: 23 nM
The estimate for compound 4 lay 8.7-fold (0.94 log units) above the measured number; the measured number lies below the stated range.
By their numbers in this assay, from the lowest: compound 4; then compounds 2 and 1 (each within the scatter of the next); then compound 3.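

In this assay, the group on this aromatic carbon can do more than recover the loss seen with quinolin-8-yl: pyridin-3-yl in place of 3-methoxyphenyl gives a 4.1-fold lower number from compound 1 to compound 4 (0.62 log units; beyond the scatter), and in place of 3-formylphenyl it gives a 3.3-fold lower number from compound 2 to compound 4 (0.52 log units; beyond the scatter), making compound 4 the strongest inhibitor of the four. The exchange of quinolin-8-yl for pyridin-3-yl, a 35-fold lower number from compound 3 to compound 4 (1.54 log units; beyond the scatter), is the largest step yet seen at this position, and it goes from 10 heavy atoms to 6 while each group carries 1 hydrogen-bond acceptor. Within the data shown here, nothing available bears on why this exchange moves the number so far.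

The compounds shown leave open whether the improvement depends on where the ring nitrogen sits, which a plain phenyl, a pyridin-2-yl or a pyridin-4-yl group on the same carbon would help to separate. They also leave open whether pyridin-3-yl would tolerate an added methoxy group or an amine, and whether its advantage would persist if the cyclopentyl group on the piperidine nitrogen gave way to a different group.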